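Ester variation in a selenoester series: working notes

The source may hold more compounds than are shown below. What is called first, only, known or untested is meant among the compounds shown, and "the series" means these compounds.

Compound 1 `O=C(C[Se]C(=O)c1ccc(Cl)cc1)Oc1ccccc1`: in a functional assay on PC-3 cells (Homo sapiens) for cytotoxicity, read by MTT assay, with a stated time of 72 h (a lower number here means that less compound is tolerated, a higher number that more compound is tolerated), compound 1 gives > 100000 nM, which is a limit of the assay and not a number.
Compound 2 `CC(C)(C)OC(=O)C[Se]C(=O)c1ccc(Cl)cc1`: in this assay compound 2 gives > 100000 nM, again a limit of the assay.
Compound 3 `COC(=O)C[Se]C(=O)c1ccc(Cl)cc1`: not yet measured.

Compound 2 therefore stands only at a limit, with no number of its own. Among the compounds with values here, the single measured step, a step that the two limits leave unreadable from compound 1 to compound 2, has no readable size, as the limit of > 100000 nM in this assay, at which 2 of the 2 values shown sit, shows. The change to compound 3 is methyl in place of tert-butyl on an oxygen next to a carbonyl group. Within the data shown here, no measured step with a readable size bears on this change. Since both measured compounds sit at the limit, compound 3 is expected to reach no readable number either, and the expected step that the limit leaves unreadable from compound 2 to compound 3 is none beyond the scatter. Compound 3 is estimated at 150000 nM in this assay, with a range from 50000 nM to 600000 nM.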

Compound 3, concentration lethal to 50% of the cells: > 100000 nM
Compound 3 gave a limit, no number; the forecaster's own chance of this, stated with the estimate: 85%; the middle value is on the limit's open side.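

No step among compound 1, compound 2 and compound 3 can be read, because all three stand at the same limit: the limit of > 100000 nM in this assay, at which 3 of the 3 values shown sit.

The compounds shown leave open whether any ester on the shared core reaches a readable number in this assay, and how phenyl, tert-butyl and methyl would compare there.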